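Methyl on the Aryl Ring of a Sphingosine Receptor Antagonist Series

The source may report more compounds than this note shows. Statements on the series, on what has been measured and on what is new or still open speak of the compounds shown alone.

Compound 1 `CCOc1cc(NC(=O)NCc2cc(C)c(-c3cn(C)nc3C(F)(F)F)nn2)cc(C#N)n1` was tested in a functional assay on CHO cells for antagonist activity at sphingosine 1-phosphate receptor 2 (Homo sapiens), read by scintillation counting and GTPgammaS binding, with a stated time of 4 h, in the presence of a further agent that is not named here (on this read-out higher numbers stand for weaker inhibition and lower numbers for stronger inhibition), and gave 35 nM. Compound 3 `CCOc1nc(C#N)cc(NC(=O)NCc2cc(C)c(-c3cn(C)nc3C(F)(F)F)nn2)c1C` shares its core, and in this assay compound 3 gave 24 nM; the step of a 1.5-fold lower number from compound 1 to compound 3 (0.16 log units; within the scatter) came from the change (methyl in place of hydrogen on an aromatic carbon). Compound 2 `Cc1cc(CNC(=O)Nc2cc(OCCO)nc(C(F)(F)F)c2)nnc1-c1cn(C)nc1C(F)(F)F` carries a different core, and the difference between the two cores is not broken down here; in this assay compound 2 gave 704 nM, the weakest of the three measured compounds, with its steps to compound 1 and compound 3 both beyond the scatter.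

Compound 4 `Cc1cc(CNC(=O)Nc2cc(C(F)(F)F)nc(OCCO)c2C)nnc1-c1cn(C)nc1C(F)(F)F` has not yet been measured. It differs from compound 2 by methyl in place of hydrogen on an aromatic carbon. This is the same kind of change as that from compound 1 to compound 3, though the surroundings differ: in compound 4 the methyl sits ortho to a 2-hydroxyethoxy group and para to a trifluoromethyl group, whereas in compound 3 it sits ortho to an ethoxy group and para to a cyano group. Because the earlier step was a 1.5-fold lower number from compound 1 to compound 3 (0.16 log units; within the scatter), the step expected for compound 4 is a 1.5-fold lower number from compound 2 to compound 4 (0.18 log units; within the scatter), a small one. Compound 4 is thus estimated at 470 nM, with a likely range from 200 nM to 1400 nM.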

Compound 4, half-maximal inhibitory concentration: 169 nM
Compound 4: the middle estimate sits 2.8-fold (0.44 log units) above what was measured; the whole stated range lies above it.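

In this assay, methyl on the aromatic carbon ortho to a 2-hydroxyethoxy group gave a 4.2-fold lower number from compound 2 to compound 4 (0.62 log units; beyond the scatter), and this step did not match the one seen for the same change on the core of compound 1: the same change on two cores in this assay, a 1.5-fold lower number (0.16 log units; within the scatter) from compound 1 to compound 3 and a 4.2-fold lower number (0.62 log units; beyond the scatter) from compound 2 to compound 4, 2.9-fold (0.46 log units) apart, beyond the scatter of two such steps The change therefore did not carry over from one core to the other with the same size, so the step on the core of compound 1 was a poor guide to the size of the step on the core of compound 2. Among the compounds shown here, with only two pairs, and with the earlier step within the scatter, this shows no general rule for the series, nor does it show which difference between the cores accounts for the gap.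

Going by these compounds, it remains open whether the larger step goes with the 2-hydroxyethoxy group, with the trifluoromethyl group or with the two together, since compound 1 and compound 2 differ in both. Also open, on these data alone, is how an ethyl group or a chlorine atom would behave on the same carbon, or how the step would change with an amine at the end of the chain in place of the hydroxyl.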